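Swapping the halogenated phenyl on a hydroxyl-bearing chain

The source may report more compounds than this note shows. Statements on the series, on what has been measured and on what is new or still open speak of the compounds shown alone.

Measured so far:
compound 1, `OC(CCn1nc2c(Br)c(Br)c(Br)c(Br)c2n1)c1cccc(Br)c1`: 0%
compound 2, `OC(CCn1nc2c(Br)c(Br)c(Br)c(Br)c2n1)c1cccc(Cl)c1`: 0.5%
compound 3, `C[C@@H](O)CCn1nc2c(Br)c(Br)c(Br)c(Br)c2n1`: 0%

In a functional assay on MCF7 cells (Homo sapiens) for antiproliferative activity, read by MTT assay, with a stated time of 48 h, tested at 100 uM (on this read-out lower numbers stand for a stronger effect and higher numbers for a weaker effect at the one concentration tested), compound 2 gives 0.5%. Compound 1, its nearest neighbour, and compound 3, the furthest, both sit within the scatter of compound 2, so the three measured compounds cannot be told apart on this read-out; none of them shows an effect that rises above the noise.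

The next compound, compound 4, `OC(CCn1nc2c(Br)c(Br)c(Br)c(Br)c2n1)c1ccc(Br)cc1`, differs from compound 2 in one place: 4-bromophenyl in place of 3-chlorophenyl on a saturated chain carbon bound to an oxygen on a saturated carbon and a saturated chain carbon. Two things change at once here: the halogen on the phenyl and where on the phenyl it sits.

Going by the values given here, only one measured step bears on this. Exchanging chloro for bromo on an aromatic carbon gave a number 0.5 percentage points higher from compound 1 to compound 2 (within the scatter), a step within the scatter. Among the compounds with values here, no measured pair speaks to moving the halogen to another position on the phenyl, so that part of the change is unsupported by data. Within the data shown here, since every measured compound sits at the floor of this assay and the one relevant step was flat, the expectation is a step of no change at the digits printed from compound 2 to compound 4 (within the scatter), that is, none beyond the scatter.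

Compound 4 is therefore estimated at 0.5%, with a range from 0% to 10%.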

Compound 4, a percentage reported as activity, at one concentration (the size of the read-out at that concentration, not a potency): 0%
Compound 4: middle estimate off by 0.5 percentage points, on the high side; measured number inside the range.
By their numbers in this assay, from the lowest: compounds 1, 3, 4 and 2 (each within the scatter of the next).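

In this assay, the position of the halogen on the phenyl now has a measured step of its own: 4-bromophenyl in place of 3-bromophenyl gives no change at the digits printed from compound 1 to compound 4 (within the scatter), with the halogen kept the same. Changing the halogen and its position together, 4-bromophenyl in place of 3-chlorophenyl, gives a number 0.5 percentage points lower from compound 2 to compound 4 (within the scatter), so on this read-out neither kind of change separates the compounds that carry a halogenated phenyl. No measurement is available here to explain this flat result.

From the compounds shown here alone, it remains open whether an amine or a carboxylic acid in place of the halogen on the phenyl, or a longer chain on the core, would give a number clearly apart from these. Going by these compounds, each compound also has a reading at only one concentration, so what happens at lower concentrations stays open, and with it whether compound 1, compound 2 and compound 4 would differ there.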